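2-Chlorophenyl for 2,3-dimethoxyphenyl on the shared core

The source may hold more compounds than are shown below. What is called first, only, known or untested is meant among the compounds shown, and "the series" means these compounds.

Measured so far in a functional assay on microsomes for inhibition, with a stated time of 1 h; a higher number here means a weaker inhibitor, a lower number a stronger inhibitor:
- compound 1 `CCOC(=O)c1cnn(-c2nc(-c3cccc(OC)c3OC)c(C#N)c(=O)n2C)c1N`: 57 ug/mL
- compound 2 `Cn1c(NN)nc(-c2cccs2)c(C#N)c1=O`: 68 ug/mL

Among the compounds with values here, only two numbers are available. Compound 1 at 57 ug/mL and compound 2 at 68 ug/mL lie within the scatter of each other, so neither stands apart in this assay.

The next compound to be measured is compound 3 `CCOC(=O)c1cnn(-c2nc(-c3ccccc3Cl)c(C#N)c(=O)n2C)c1N`. It carries 2-chlorophenyl in place of 2,3-dimethoxyphenyl on an aromatic carbon, next to the ring nitrogen and ortho to a cyano group (2-chlorophenyl in place of 2,3-dimethoxyphenyl on an aromatic carbon). Within the data shown here, no measured pair isolates this change, so the data show neither its size nor its direction. The expectation therefore rests on compound 1 at 57 ug/mL, with no shift beyond the scatter in either direction. The estimated change is a 1.1-fold higher number from compound 1 to compound 3 (0.02 log units; within the scatter). Compound 3 is expected at 60 ug/mL, with an estimated range of 25 ug/mL to 140 ug/mL.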

Compound 3, half-maximal inhibitory concentration: 102 ug/mL
Compound 3: middle estimate off by 1.7-fold (0.23 log units), on the low side; measured number inside the range.
By their numbers in this assay, from the lowest: compounds 1, 2 and 3 (each within the scatter of the next).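

In this assay, within the data shown here, compounds 1 and 3 form the first pair that isolates this position, on an aromatic carbon ortho to a cyano group, and the step is a 1.8-fold higher number from compound 1 to compound 3 (0.25 log units; within the scatter). Exchanging 2,3-dimethoxyphenyl for 2-chlorophenyl therefore does not separate the two compounds, even though the entering group has no hydrogen-bond acceptors and fewer heavy atoms than the group it replaces. No measurement in hand accounts for this result.

This single pair does not show whether the position would respond to a substituent of another kind, such as a phenyl ring carrying an amine or a carboxylic acid. A non-aromatic group here, such as a cyclohexyl ring or a longer alkyl chain, also remains an open case on the shared core.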